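The compounds below may be only part of what the source reports. "The series", "measured", "known", "first", "only" and "open" are said of these compounds alone.

Measured compounds:
compound 1 `O=C(Nc1ccc(Oc2ccnc3[nH]ccc23)c(F)c1)c1cc2cccnc2n(-c2ccccc2)c1=O` — 1260 nM
compound 2 `O=C(Nc1ccc(Oc2ccnc3[nH]ccc23)c(F)c1)c1cc2cccnc2n(-c2ccc(C(F)(F)F)cc2Cl)c1=O` — "not determined" (no result reported)

Among the measured compounds shown here, compound 1 carries the only number in a functional assay on U-87MG ATCC cells for antiproliferative activity against U-87 MG (Homo sapiens), read by MTT assay, with a stated time of 72 h (on this read-out higher numbers stand for weaker inhibition and lower numbers for stronger inhibition), where compound 1 gives 1260 nM; compound 2 adds nothing numerical. Compound 3 `Cn1ccc2c(Oc3ccc(NC(=O)c4cc5cccnc5n(-c5ccccc5)c4=O)cc3F)ccnc21` differs from compound 1 by methyl in place of hydrogen on an aromatic nitrogen. For the measured compounds named here, no measured pair tells how this change shifts this assay. A moderate loss is expected, beyond the usual scatter but not large, so the step of a 2.8-fold higher number from compound 1 to compound 3 (0.44 log units; beyond the scatter) is an estimate without precedent. Compound 3 is expected at 3500 nM, with a range from 1200 nM to 12000 nM.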

Compound 3, half-maximal inhibitory concentration: 3590 nM
Compound 3: middle estimate off by 1.0-fold (0.01 log units), on the low side, and the stated range covers the measured number.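

Methyl in place of hydrogen on an aromatic nitrogen of the five-membered aromatic ring gives a 2.8-fold higher number from compound 1 to compound 3 (0.45 log units; beyond the scatter) in this assay as a modest step, so this position responds to the change, yet a substituent here still leaves a measurable value. Nothing on hand accounts for the shift. As far as these compounds go, whether the loss comes from losing the hydrogen or from adding the carbon stays open. So does the outcome with a longer chain on this nitrogen, such as ethyl or 2-aminoethyl.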